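Cytotoxicity notes: from compound 2 to compound 4

A few compounds are considered here, and "the series" means these few. Any claim that something is new, unique, unknown or untested is made for them only; others in the source may bear on it.

Measured so far:
Compound 1 `CCCCNc1cc(Oc2c(OC)cc3cc(C#N)ccc3c2OC)nc(Nc2ccc(C#N)cc2)n1`: in an ADME assay on MT4 cells (Homo sapiens) for cytotoxicity, read by MTT assay, with a stated time of 5 days (a higher number here means that more compound is tolerated, a lower number that less compound is tolerated), compound 1 gives > 125000 nM, which is a limit.
Compound 2 `COc1cc2cc(C#N)ccc2c(OC)c1Oc1cc(NC(C)(C)C)nc(Nc2ccc(C#N)cc2)n1`: in this assay compound 2 gives > 125000 nM, also a limit.
Compound 3 `CCCC(CCC)Nc1cc(Oc2c(OC)cc3cc(C#N)ccc3c2OC)nc(Nc2ccc(C#N)cc2)n1`: in this assay compound 3 gives > 125000 nM, again a limit.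

Compound 2 therefore stands at the top of what the measurement can report, as do the other two values (the limit of > 125000 nM in this assay, at which 3 of the 3 values shown sit). The three steps among them, a step that the two limits leave unreadable from compound 1 to compound 2, a step that the two limits leave unreadable from compound 2 to compound 3 and a step that the two limits leave unreadable from compound 1 to compound 3, cannot be sized.

Compound 4 `COc1cc2cc(C#N)ccc2c(OC)c1Oc1cc(NCCCCO)nc(Nc2ccc(C#N)cc2)n1` differs from compound 2 in one place: 4-hydroxybutyl in place of tert-butyl on a nitrogen on an aromatic ring. Going by the values given here, no measured step in this assay bears readably on this change. Compound 4 is expected to sit at the limit again, with an estimate of 150000 nM between 60000 nM and 400000 nM. The expected step that the limit leaves unreadable from compound 2 to compound 4 is thus none beyond the scatter.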

Compound 4, half-maximal cytotoxic concentration: 39100 nM
Beside the measured number, compound 4's estimate is 3.8-fold (0.58 log units) above it, and the stated range ends above it.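

Going by these compounds alone, at the nitrogen on the aromatic ring, 4-hydroxybutyl gives the first readable change in this assay, with an at least 3.1-fold lower number from compound 2 to compound 4 (0.50 log units; beyond the scatter) and likewise an at least 3.1-fold lower number from compound 3 to compound 4 (0.50 log units; beyond the scatter). Hydroxy in place of hydrogen on the butyl chain is enough on its own for an at least 3.1-fold lower number from compound 1 to compound 4 (0.50 log units; beyond the scatter). All three steps are minimum sizes because each starts from a limit: the limit of > 125000 nM in this assay, at which 3 of the 4 values shown sit.

The steps among compound 1, compound 2 and compound 3 cannot be read, so the alkyl groups remain unranked. On these data alone, whether an amine or a carboxylic acid in place of the hydroxy, or a longer chain carrying it, would give a similar step stays open.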